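This account rests on a few compounds, and the source may have more. Where it says the series, first, only, none or still open, it means among the compounds named here.

Working notes on the series. Compound 1 `CCCCCCC1(O)C(=O)Nc2ccc(Nc3ccc(C)cc3)cc21` carries a pentyl group and a methyl group on its aryl ring. In a functional assay on NCI-H460 cells (Homo sapiens) for antiproliferative activity, read by MTT assay, with a stated time of 48 h (on this read-out higher numbers stand for weaker inhibition and lower numbers for stronger inhibition), compound 1 gives only a limit, > 100000 nM, as recorded in the limit of > 100000 nM in this assay, at which 1 of the 3 values shown sits. Compound 2 `Cc1ccc(Nc2ccc3c(c2)C(O)(Cc2ccccc2)C(=O)N3)cc1` differs by phenyl in place of pentyl on a saturated chain carbon bound to a saturated ring carbon; in this assay compound 2 gives 31600 nM, a change of an at least 3.1-fold lower number from compound 1 to compound 2 (0.50 log units; beyond the scatter). Compound 3 `CCCCCCC1(O)C(=O)Nc2ccc(Nc3ccc(C(F)(F)F)cc3)cc21` differs from compound 1 in its core by trifluoromethyl in place of methyl on an aromatic carbon; in this assay compound 3 gives 18800 nM, a change of an at least 5.3-fold lower number from compound 1 to compound 3 (0.72 log units; beyond the scatter). Compound 4 `O=C1Nc2ccc(Nc3ccc(C(F)(F)F)cc3)cc2C1(O)Cc1ccccc1` is not yet measured; it differs from compound 3 by phenyl in place of pentyl on a saturated chain carbon bound to a saturated ring carbon, the same change as that from compound 1 to compound 2, at the same place. For compound 4 the expected step is a 3.1-fold lower number from compound 3 to compound 4 (0.50 log units; beyond the scatter). This expectation rests on the same change measured as an at least 3.1-fold lower number from compound 1 to compound 2 (0.50 log units; beyond the scatter). Compound 4 is estimated at 6000 nM, with a range from 2500 nM to 15000 nM.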

Compound 4, half-maximal inhibitory concentration: 9100 nM
The estimate for compound 4 lay 1.5-fold (0.18 log units) below the measured number; the measured number falls inside the stated range.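

In this assay the change of pentyl to phenyl keeps its direction on the second core, with a 2.1-fold lower number from compound 3 to compound 4 (0.32 log units; beyond the scatter), and the two steps compare thus: the same change on two cores in this assay, an at least 3.1-fold lower number (0.50 log units; beyond the scatter) from compound 1 to compound 2 and a 2.1-fold lower number (0.32 log units; beyond the scatter) from compound 3 to compound 4; the limit leaves it open whether they differ

The change of methyl to trifluoromethyl also keeps its direction, with a 3.5-fold lower number from compound 2 to compound 4 (0.54 log units; beyond the scatter), and the two steps compare thus: the same change on two cores in this assay, an at least 5.3-fold lower number (0.72 log units; beyond the scatter) from compound 1 to compound 3 and a 3.5-fold lower number (0.54 log units; beyond the scatter) from compound 2 to compound 4; the limit leaves it open whether they differ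

Each change therefore points the same way on both cores, but this does not show that its size carries over, as compound 1 gives only a limit: the limit of > 100000 nM in this assay, at which 1 of the 4 values shown sits.

The compounds shown leave open how a chain longer than pentyl would read in this assay. They also leave open the effect of an amine or a carboxylic acid in place of trifluoromethyl on the aromatic carbon.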